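The source may report more compounds than this note shows. Statements on the series, on what has been measured and on what is new or still open speak of the compounds shown alone.

Compound 2 `O=C1/C(=C/c2cccc(Cl)c2)Cc2cc(O)ccc21` gives the lowest of the two numbers recorded in an assay on isolated protein for inhibition of Amine oxidase [flavin-containing] B (Homo sapiens), read by fluorescence and spectrophotometry, with a stated time of 20 min (on this read-out higher numbers stand for weaker inhibition and lower numbers for stronger inhibition), at 30 nM. For the measured compounds named here, its nearest neighbour is compound 1 `O=C1/C(=C/c2ccccc2)Cc2cc(O)ccc21`, which in this assay gives 376 nM; the single measured step, a 13-fold lower number from compound 1 to compound 2 (1.10 log units; beyond the scatter), is the one that separates them and arises from chloro in place of hydrogen on an aromatic carbon.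

Compound 3 `Cc1cccc(/C=C2\Cc3cc(O)ccc3C2=O)c1` differs from compound 2 by methyl in place of chloro on an aromatic carbon, the new group sitting on an aromatic carbon of a six-membered aromatic ring of carbon only, meta to a large group. Going by the values given here, only one measured step bears on this change: a 13-fold lower number from compound 1 to compound 2 (1.10 log units; beyond the scatter), which shows that placing chloro on this carbon moved the number a long way down from the unsubstituted compound 1. Among the compounds with values here, no measured step compares methyl with chloro at this position, so the direction of the exchange is not fixed by the data. Compound 3 is therefore expected to stay close to compound 2, with a step of a 2.0-fold higher number from compound 2 to compound 3 (0.30 log units; within the scatter) in this assay, and its value is estimated at 60 nM, within a range from 20 nM to 180 nM.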

Compound 3, half-maximal inhibitory concentration: 52 nM
Compound 3: the middle estimate sits 1.2-fold (0.06 log units) above what was measured; the range from low to high includes it.
By their numbers in this assay, from the lowest: compounds 2 and 3 (each within the scatter of the next); then compound 1.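

In this assay the exchange of chloro for methyl gives a 1.7-fold higher number from compound 2 to compound 3 (0.24 log units; within the scatter), so the two groups cannot be ranked at this carbon. Until now, only chloro had been seen to lower the number from the unsubstituted compound 1; the step of a 7.2-fold lower number from compound 1 to compound 3 (0.86 log units; beyond the scatter) shows that methyl does so as well, and the drop is therefore not confined to chloro. For the compounds shown here, each of the two groups is a single heavy atom with no hydrogen-bond donor or acceptor, so the lowering is so far seen only with groups of that description.

The compounds shown leave open whether a larger or differently built group on this carbon, such as methoxy, an amine, a carboxylic acid or a longer chain, would keep the number as low as chloro and methyl do. They also leave open how chloro or methyl would behave on another carbon of the same ring, as every step here concerns this one position. Nothing given here accounts for the effect of either group on the number.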